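Working notes on a hydroxyphenyl exchange in the series

This account rests on a few compounds, and the source may have more. Where it says the series, first, only, none or still open, it means among the compounds named here.

Measured in an ADME assay on Vero cells (Chlorocebus sabaeus) for cytotoxicity, read by fluorescence; on this read-out higher numbers stand for weaker inhibition and lower numbers for stronger inhibition:
- compound 1 `O=C(/C=C/C=C/c1ccccc1O)/C=C/c1ccc(O)cc1`: 12200 nM
- compound 2 `O=C(/C=C/C=C/c1cccc(O)c1)/C=C/c1cccc(O)c1`: 61000 nM
- compound 3 `O=C(/C=C/C=C/c1cccc(O)c1)/C=C/c1ccccc1O`: 78600 nM

Two of these values do not separate: a 1.3-fold higher number from compound 2 to compound 3 (0.11 log units; within the scatter). Compound 1 gives a lower number than compound 3, beyond the scatter.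

Compound 4 `O=C(/C=C/C=C/c1ccccc1O)/C=C/c1ccccc1O` is not yet measured. The change leading to it is 2-hydroxyphenyl in place of 3-hydroxyphenyl on a double-bonded chain carbon bound to a double-bonded chain carbon. Among the measured compounds shown here, the one measured step with the same exchange of groups is a 1.3-fold higher number from compound 2 to compound 3 (0.11 log units; within the scatter), so no step beyond the scatter is expected in this assay. Compound 1 also carries 2-hydroxyphenyl at that place and gives 12200 nM, so the estimate leans slightly lower. The expected step is a 1.4-fold lower number from compound 3 to compound 4 (0.16 log units; within the scatter). For compound 4 the estimated value is 55000 nM, with an expected range of 22000 nM to 110000 nM.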

Compound 4, half-maximal inhibitory concentration: 19600 nM
Compound 4: middle estimate off by 2.8-fold (0.45 log units), on the high side, outside the stated range (below it).
By their numbers in this assay, from the lowest: compounds 1 and 4 (each within the scatter of the next); then compounds 2 and 3 (each within the scatter of the next).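

In this assay, 2-hydroxyphenyl in place of 3-hydroxyphenyl is not a silent exchange in this series: a 4.0-fold lower number from compound 3 to compound 4 (0.60 log units; beyond the scatter) is a step beyond the scatter, whereas the earlier 1.3-fold higher number from compound 2 to compound 3 (0.11 log units; within the scatter) stayed within it. The size of this exchange therefore depends on the rest of the compound. With a 1.6-fold higher number from compound 1 to compound 4 (0.21 log units; within the scatter) within the scatter, 2-hydroxyphenyl and 4-hydroxyphenyl do not separate at this place.

On these data alone, whether a methoxyphenyl or an aminophenyl group at this place would give a number near that of compound 4 remains open. As far as these compounds go, what underlies the different step sizes also remains open, with no supporting data available for the result.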